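The compounds below may be only part of what the source reports. "The series", "measured", "known", "first", "only" and "open" are said of these compounds alone.

In an ADME assay on BJ cells (Homo sapiens) for inhibition, read by fluorescence and resazurin assay, with a stated time of 72 h (on this read-out lower numbers stand for stronger inhibition of growth and higher numbers for weaker inhibition of growth), compound 3 `N[C@H]1CC[C@H](Nc2nc(Nc3ccc(-c4ccccc4O)nc3)c3ncn(C4CCCC4)c3n2)CC1` gives 6350 nM, the second highest of the three numbers recorded. Compound 2 `COc1ccccc1-c1ccc(Nc2nc(N[C@H]3CC[C@H](N)CC3)nc3c2ncn3C2CCCC2)cn1` gives 6200 nM, and the step of a 1.0-fold higher number from compound 2 to compound 3 (0.01 log units; within the scatter) stays within the scatter. Compound 1 `N[C@H]1CC[C@H](Nc2nc(Nc3ccc(-c4ccoc4)nc3)c3ncn(C4CCCC4)c3n2)CC1` gives 13100 nM, the highest of the three; the steps of a 2.1-fold lower number from compound 1 to compound 3 (0.31 log units; beyond the scatter) and a 2.1-fold lower number from compound 1 to compound 2 (0.32 log units; beyond the scatter) were modest. Compound 4 `COc1ccc(-c2ccc(Nc3nc(N[C@H]4CC[C@H](N)CC4)nc4c3ncn4C3CCCC3)cn2)cc1` is still to be measured. It differs from compound 3 by 4-methoxyphenyl in place of 2-hydroxyphenyl on an aromatic carbon. For the measured compounds named here, the only measured step that bears on this, a 1.0-fold higher number from compound 2 to compound 3 (0.01 log units; within the scatter), exchanged hydrogen for methyl on the ring oxygen and stayed within the scatter, while no measured pair tests a 4-methoxyphenyl group. Compound 4 is therefore expected to show a step of a 1.1-fold higher number from compound 3 to compound 4 (0.04 log units; within the scatter) that stays within the scatter. Compound 4 is estimated at 7000 nM, with a range from 3000 nM to 16000 nM.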

Compound 4, concentration for 50% growth inhibition: 7230 nM
Compound 4: the middle estimate sits 1.0-fold (0.01 log units) below what was measured, within the range that was stated.
By their numbers in this assay, from the lowest: compounds 2, 3, 4 and 1 (each within the scatter of the next, the first and the last beyond it).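

In this assay the place of the methoxy group on the phenyl ring shows no effect at this position, with a 1.2-fold higher number from compound 2 to compound 4 (0.07 log units; within the scatter) and a 1.1-fold higher number from compound 3 to compound 4 (0.06 log units; within the scatter) both inside the scatter. Unlike the steps to the two ortho-free comparison compounds, a 1.8-fold lower number from compound 1 to compound 4 (0.26 log units; within the scatter) also stays within the scatter, so a clear separation from furan-3-yl does not hold for every substituted phenyl group. Nothing available explains these results. 

Going by these compounds, whether an amine or a carboxylic acid on this phenyl ring would shift growth inhibition remains open. So does the effect of a longer chain in place of the methoxy group.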